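The source may report more compounds than this note shows. Statements on the series, on what has been measured and on what is new or still open speak of the compounds shown alone.

The measured compounds:

Compound 1, `COc1ncnc2c1c(-c1ccoc1)cn2[C@@H]1O[C@H](CO)[C@@H](O)[C@H]1O`: in a functional assay on K562 cells (Homo sapiens), read by MTT assay, with a stated time of 72 h (on this read-out lower numbers stand for stronger inhibition and higher numbers for weaker inhibition), compound 1 gives 190 nM.
Compound 2, `CN(C)c1ncnc2c1c(-c1ccoc1)cn2[C@@H]1O[C@H](CO)[C@@H](O)[C@H]1O`: in this assay compound 2 gives 1540 nM.
Compound 3, `CN(C)c1ncnc2c1c(-c1cc3ccccc3o1)cn2[C@@H]1O[C@H](CO)[C@@H](O)[C@H]1O`: in this assay compound 3 gives only a limit of the assay, > 20000 nM.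

Compounds 1 and 2 share one core and differ by one change, (methoxy in place of dimethylamino on an aromatic carbon), which gave an 8.1-fold lower number from compound 2 to compound 1 (0.91 log units; beyond the scatter). Compounds 2 and 3 differ in the core, (1-benzofuran-2-yl in place of furan-3-yl on an aromatic carbon), which gave an at least 12-fold higher number from compound 2 to compound 3 (1.11 log units; beyond the scatter), with compound 3 sitting at the limit of > 20000 nM in this assay, at which 1 of the 3 values shown sits.

Compound 4, `COc1ncnc2c1c(-c1cc3ccccc3o1)cn2[C@@H]1O[C@H](CO)[C@@H](O)[C@H]1O`, is not yet measured. It differs from compound 3 by methoxy in place of dimethylamino on an aromatic carbon, and the surroundings of that change read the same, word for word, as for the change from compound 2 to compound 1, so it is the same change made on the other core. For compound 4 the expected step is an at least 2.5-fold lower number from compound 3 to compound 4 (0.39 log units; beyond the scatter), which rests on an 8.1-fold lower number from compound 2 to compound 1 (0.91 log units; beyond the scatter). Since compound 3 is known only as a limit, the starting point is uncertain, and compound 4 may again return only a limit. Compound 4 is expected near 8000 nM in this assay, between 2000 nM and 40000 nM.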

Compound 4, half-maximal inhibitory concentration: 20900 nM
Estimate against measurement, compound 4: 2.6-fold (0.42 log units) below, and the stated range covers the measured number.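

In this assay, 1-benzofuran-2-yl in place of furan-3-yl gave a 110-fold higher number from compound 1 to compound 4 (2.04 log units; beyond the scatter), so the same swap raised the number on both cores, whether the compounds carried methoxy or dimethylamino. Set side by side, the two steps show agreement in direction but not in size: the same change on two cores in this assay, an at least 12-fold higher number (1.11 log units; beyond the scatter) from compound 2 to compound 3 and a 110-fold higher number (2.04 log units; beyond the scatter) from compound 1 to compound 4; the limit leaves it open whether they differ. Compound 3 stands at > 20000 nM, a limit of the assay, so the step to compound 4 cannot be read, and the compounds do not show whether methoxy in place of dimethylamino, which lowered the number on the core of compound 2, does the same on the core of compound 3.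

The compounds shown leave open how a primary amine or an ethoxy group would compare with methoxy and dimethylamino on either core. They also leave open whether a phenyl or thiophene group in place of furan-3-yl would keep the lower numbers or follow 1-benzofuran-2-yl towards the higher ones.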